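This account rests on a few compounds, and the source may have more. Where it says the series, first, only, none or still open, it means among the compounds named here.

Compound 1 `COc1ccc(-c2cnc(NC(=O)c3ccccc3F)n2C)cc1` and compound 2 `COc1ccc(-c2cnc(NC(=O)c3ccc(C#N)cc3)n2C)cc1` share one core and differ only in the group on the carbonyl carbon. In a toxicity assay on THP-1 cells (Homo sapiens) for inhibition (a lower number here means that less compound is tolerated, a higher number that more compound is tolerated), compound 1 gives a limit of the assay rather than a number, > 100000 nM. In this assay compound 2 also gives only a limit, > 100000 nM. The step that the two limits leave unreadable from compound 1 to compound 2 therefore cannot be read, because both values sit at the limit of > 100000 nM in this assay, at which 2 of the 2 values shown sit. Compound 3 `COc1ccc(-c2cnc(NC(=O)c3ccccc3Cl)n2C)cc1` differs from compound 2 by 2-chlorophenyl in place of 4-cyanophenyl on a carbonyl carbon. With no readable step to draw on, the expected step that the limit leaves unreadable from compound 2 to compound 3 is none beyond the scatter. Compound 3 is estimated at 150000 nM, within 60000 nM to 400000 nM, most likely again a limit.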

Compound 3, half-maximal cytotoxic concentration: > 50000 nM
Compound 3 gave a limit, no number; the forecaster's own chance of this, stated with the estimate: 80%; the middle value is on the limit's open side.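

For the compounds shown here, compound 3 also gives only a limit in this assay, > 50000 nM, so no step among compound 1, compound 2 and compound 3 can be read. The compounds shown leave open whether changing the group on the carbonyl carbon shifts the half-maximal cytotoxic concentration at all.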